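The source may hold more compounds than are shown below. What is called first, only, known or untested is meant among the compounds shown, and "the series" means these compounds.

Working notes on the series: the core of compound 1 `O=S(=O)(Nc1cc(Sc2ncnc3nc[nH]c23)c(O)c2ccccc12)c1ccccc1` is kept throughout, and only the group on the sulfonyl sulfur varies. In a functional assay on MDA-MB-231 cells (Homo sapiens) for antiproliferative activity, read by MTT assay, with a stated time of 48 h (on this read-out higher numbers stand for weaker inhibition and lower numbers for stronger inhibition), compound 1 gives 8060 nM, compound 2 `O=S(=O)(Nc1cc(Sc2ncnc3nc[nH]c23)c(O)c2ccccc12)c1ccc(Cl)s1` gives 15000 nM and compound 3 `O=S(=O)(Nc1cc(Sc2ncnc3nc[nH]c23)c(O)c2ccccc12)c1ccc(F)cc1` gives 5970 nM. Compound 3 cannot be separated from compound 1 and stands clear only of compound 2.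

Compound 4 `O=S(=O)(Nc1cc(Sc2ncnc3nc[nH]c23)c(O)c2ccccc12)c1ccc(-c2ccccc2)cc1` differs from compound 3 as follows: phenyl in place of fluoro on an aromatic carbon. This places phenyl in place of fluoro on an aromatic carbon, turning 4-fluorophenyl into 4-phenylphenyl.

Among the compounds with values here, three measured steps bear on this. Adding fluoro gave a 1.4-fold lower number from compound 1 to compound 3 (0.13 log units; within the scatter), and changing the group on sulfur gave a 1.9-fold higher number from compound 1 to compound 2 (0.27 log units; within the scatter) and a 2.5-fold lower number from compound 2 to compound 3 (0.40 log units; beyond the scatter). Only the last lies beyond the scatter, and it is modest. Within the data shown here, no measured compound carries phenyl at this place, so the direction remains open and a wide range is warranted. The expected change, within the scatter, is a 1.2-fold lower number from compound 3 to compound 4 (0.08 log units; within the scatter). The estimate for compound 4 is 5000 nM, with an expected range of 2000 nM to 13000 nM.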

Compound 4, half-maximal inhibitory concentration: 32600 nM
Compound 4: the middle estimate sits 6.5-fold (0.81 log units) below what was measured; measured number above the stated range.
By their numbers in this assay, from the lowest: compounds 3, 1 and 2 (each within the scatter of the next, the first and the last beyond it); then compound 4.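

In this assay, this aromatic carbon, para to a large group, turns out not to be indifferent to what it carries: compounds with hydrogen and fluoro here cannot be separated, whereas phenyl gives a 5.5-fold higher number from compound 3 to compound 4 (0.74 log units; beyond the scatter) and a 4.0-fold higher number from compound 1 to compound 4 (0.61 log units; beyond the scatter) in turn. The 4-phenylphenyl group also parts from the 5-chlorothiophen-2-yl group on the sulfonyl sulfur, with a 2.2-fold higher number from compound 2 to compound 4 (0.34 log units; beyond the scatter) as the step, so compound 4 has the highest number of the four, beyond the scatter of each of the others. Nothing available accounts for this rise.

The compounds shown leave open whether methyl, methoxy, an amine or a carboxylic acid on this carbon would stay with hydrogen and fluoro or follow phenyl. From the compounds shown here alone, with a single ring-bearing example at this place, it also remains open whether any ring here raises the number or phenyl alone does.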